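Aryl exchange on the aromatic nitrogen in this antiproliferative series

A few compounds are considered here, and "the series" means these few. Any claim that something is new, unique, unknown or untested is made for them only; others in the source may bear on it.

In an ADME assay on HUVEC cells (Homo sapiens) for antiproliferative activity, read by MTT assay, with a stated time of 48 h (a lower number here means a stronger inhibitor, a higher number a weaker inhibitor), compound 2 `CCc1cccc(C)c1-n1nncc1CN1C(=O)C2(C(C#N)=C(N)Oc3c(N)cc4nc5ccccc5nc4c32)c2ccccc21` returns only a limit, > 50000 nM, not a number. Compound 1 `N#CC1=C(N)Oc2c(c3nc4ccccc4nc3c3ccccc23)C12C(=O)N(Cc1cnnn1-c1cccc(Cl)c1)c1ccccc12` likewise returns only a limit, > 50000 nM. Both results sit at the limit of > 50000 nM in this assay, at which 2 of the 2 values shown sit, so compound 2 stands at the limit of the numbers shown, and nothing separates it from compound 1. Going by the values given here, no step between measured compounds can be drawn; the two values show only that neither compound reached a measurable half-maximal inhibitory concentration within the tested range.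

Compound 3 `COc1cc(-n2nncc2CN2C(=O)C3(C(C#N)=C(N)Oc4c(N)cc5nc6ccccc6nc5c43)c3ccccc32)c(OC)cc1Cl` differs from compound 2 in one place: 4-chloro-2,5-dimethoxyphenyl in place of 2-ethyl-6-methylphenyl on an aromatic nitrogen. Among the compounds with values here, with no measured step available, the estimated step is a number no higher from compound 2 to compound 3 (the limit leaves the size open), which means nothing beyond the scatter, and the result is most likely again only a limit. Compound 3 is therefore expected near 50000 nM, with a range of 15000 nM to 150000 nM in this assay.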

Compound 3, half-maximal inhibitory concentration: > 50000 nM
Compound 3 was reported as a limit; the forecaster's own chance of this, stated with the estimate: 80%; the middle value sits exactly at the limit.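

Compound 3 returns only a limit in this assay, > 50000 nM, and no step can be read between compound 2 and compound 3: the limit of > 50000 nM in this assay, at which 3 of the 3 values shown sit.

The compounds shown leave open whether any aryl group on this aromatic nitrogen gives a measurable half-maximal inhibitory concentration in this assay.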